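Acyl triazenes: acyl group exchange on the amide carbonyl

This account rests on a few compounds, and the source may have more. Where it says the series, first, only, none or still open, it means among the compounds named here.

Measured so far:
compound 1, `O=C(c1ccccc1F)N(/N=N/c1ccc([N+](=O)[O-])cc1Cl)c1ccc([N+](=O)[O-])cc1Cl`, 2350 nM
compound 2, `O=C(c1ccccc1F)N(/N=N/c1ccc([N+](=O)[O-])cc1C(F)(F)F)c1ccc([N+](=O)[O-])cc1C(F)(F)F`, 800 nM

In a functional assay on HeLa cells (Homo sapiens) for cytotoxicity, read by MTT assay, with a stated time of 72 h (on this read-out lower numbers stand for stronger inhibition and higher numbers for weaker inhibition), compound 1 gives 2350 nM. In the same this assay compound 2 gives 800 nM, the lowest of the two numbers; compound 1 lies at a higher number, and that gap is beyond the scatter. Going by the values given here, compounds 1 and 2 differ in more than one place, so their two values show only that compound 2 is the stronger of the pair.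

Compound 3, `CCOC(=O)CC(=O)N(/N=N/c1ccc([N+](=O)[O-])cc1C(F)(F)F)c1ccc([N+](=O)[O-])cc1C(F)(F)F`, is the next candidate for this assay. It keeps the core of compound 2 and differs from it in one place: (ethoxycarbonyl)methyl in place of 2-fluorophenyl on a carbonyl carbon. Among the compounds with values here, no measured pair shows a change of this kind, so the step size is not anchored by data. Replacing an aromatic ring with an open ester-bearing chain at the amide carbonyl is expected to move the number upward by a small to moderate step, a 1.9-fold higher number from compound 2 to compound 3 (0.27 log units; within the scatter), possibly still inside the scatter.

Compound 3 is estimated at 1500 nM, with a range from 500 nM to 5000 nM.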

Compound 3, half-maximal inhibitory concentration: 300 nM
For compound 3 the middle estimate is 5.0-fold (0.70 log units) above the measured one; measured number outside the range, below it.
By their numbers in this assay, from the lowest: compound 3; then compound 2; then compound 1.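

In this assay, going by these compounds alone, the exchange of 2-fluorophenyl for (ethoxycarbonyl)methyl on a carbonyl carbon, with the core of compound 2 kept, gives a 2.7-fold lower number from compound 2 to compound 3 (0.43 log units; beyond the scatter) and is the first single-place comparison. This position therefore does not need an aromatic ring to hold a low number in this read-out: the entering group has no ring and carries hydrogen-bond acceptors, whereas the leaving group has a ring and no such acceptors. No supporting data bear on why the number moves.

This one step cannot separate the loss of the ring from the gain of the ester, so a carboxylic acid in place of the ethyl ester, a longer chain, or a plain alkyl group without the ester on this carbonyl carbon would be needed to tell which part of the change matters. Also open, as far as these compounds go, is whether the same exchange gives a step of similar size on the core of compound 1.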